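The source may hold more compounds than are shown below. What is called first, only, known or untested is meant among the compounds shown, and "the series" means these compounds.

In a functional assay on A549 cells (Homo sapiens) for antiproliferative activity, read by XTT assay, with a stated time of 72 h (on this read-out lower numbers stand for stronger inhibition and higher numbers for weaker inhibition), compound 3 `COc1ccc(-c2cc3ccccc3nc2/C=C/C(=O)c2ccc(Br)s2)cc1` gives 6250 nM. Among the measured compounds shown here, its number sits among those of the two other compounds measured so far, all three within the usual scatter of one another: compound 2 `COc1ccc(-c2cc3ccccc3nc2/C=C/C(=O)c2ccccn2)cc1` gives 6140 nM, and compound 1 `COc1ccc(-c2cc3ccccc3nc2/C=C/C(=O)c2ccc(O)cc2)cc1` gives 7440 nM. The steps between them are small: a 1.2-fold lower number from compound 1 to compound 2 (0.08 log units; within the scatter), a 1.2-fold lower number from compound 1 to compound 3 (0.08 log units; within the scatter) and a 1.0-fold higher number from compound 2 to compound 3 (0.01 log units; within the scatter).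

Compound 4 `COc1ccc(-c2cc3ccccc3nc2/C=C/C(=O)c2cnc(N)nc2C)cc1` is the next compound, differing from compound 3 by 2-amino-4-methylpyrimidin-5-yl in place of 5-bromothiophen-2-yl on a carbonyl carbon. All three measured steps exchange the group on the same carbonyl carbon, and none of them moved the number beyond the scatter, whether an aromatic ring with one hetero atom or with none was set there. For the measured compounds named here, the entering group brings a hydrogen-bond donor where the leaving one had none, and this is the first such change in the set, so nothing measured speaks directly to it. The expectation for compound 4 is therefore a step of a 1.0-fold higher number from compound 3 to compound 4 (0.02 log units; within the scatter) that stays within the scatter, with an estimated value of 6500 nM and a range from 2500 nM to 17000 nM.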

Compound 4, half-maximal inhibitory concentration: > 10000 nM
Compound 4: only a limit was reported (the forecaster's own chance of this, stated with the estimate: 5%); at least 1.5-fold (0.18 log units) between middle value and limit.
By their numbers in this assay, from the lowest: compounds 2, 3 and 1 (each within the scatter of the next). At a limit, above all of these: compound 4.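

Compound 4 gives only a limit and not a number in this assay: the limit of > 10000 nM in this assay, at which 1 of the 4 values shown sits. The steps to it therefore have floors and no known size: an at least 1.6-fold higher number from compound 3 to compound 4 (0.20 log units; that floor lies within the scatter), an at least 1.6-fold higher number from compound 2 to compound 4 (0.21 log units; that floor lies within the scatter) and an at least 1.3-fold higher number from compound 1 to compound 4 (0.12 log units; that floor lies within the scatter). Among the compounds shown here, the earlier exchanges on this carbonyl carbon all gave numbers within the scatter of one another, whereas 2-amino-4-methylpyrimidin-5-yl, the first group here with two ring hetero atoms, leaves the size of the change unbounded upward, so it may be small or large.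

The compounds shown do not separate the amine from the methyl group or from the pyrimidine ring itself as the source of this result. From the compounds shown here alone, it also remains open how a plain pyrimidin-5-yl ring or a phenyl ring bearing a carboxylic acid would read at this position.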